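Cyano substitution on the benzyl ether of compound 3

The source may report more compounds than this note shows. Statements on the series, on what has been measured and on what is new or still open speak of the compounds shown alone.

Compound 3 `NC(=O)[C@@H]1CC[C@H](c2ccc(OCc3ccccc3)cc2)N1` carries an unsubstituted benzyl ether on the shared core. In an assay on HEK293 cells for inhibition of sodium channel protein type 3 subunit alpha (Homo sapiens), read by electrophysiology, with a stated time of 3.5 min (a lower number here means a stronger inhibitor, a higher number a weaker inhibitor), compound 3 gives only a limit, > 63000 nM. Compound 1 `N#Cc1ccccc1COc1ccc([C@H]2CC[C@@H](C(N)=O)N2)cc1` gives only a limit in this assay, > 63000 nM. Compound 2 `NC(=O)[C@@H]1CC[C@H](c2ccc(OCc3ccc(F)cc3)cc2)N1` likewise gives only a limit, > 63000 nM. All three values therefore sit at the same point, as noted in the limit of > 63000 nM in this assay, at which 3 of the 3 values shown sit, and none of the connecting steps can be read: a step that the two limits leave unreadable from compound 1 to compound 2, a step that the two limits leave unreadable from compound 1 to compound 3 and a step that the two limits leave unreadable from compound 2 to compound 3 are all unreadable.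

Compound 4 `N#Cc1ccc(COc2ccc([C@H]3CC[C@@H](C(N)=O)N3)cc2)cc1` differs from compound 3 by cyano in place of hydrogen on an aromatic carbon. The measured steps that bear on this change, both the loss of cyano in a step that the two limits leave unreadable from compound 1 to compound 3 and the loss of fluoro in a step that the two limits leave unreadable from compound 2 to compound 3, give no size in either direction, so no step beyond the scatter can be expected, and the most likely outcome is again a limit. Compound 4 is therefore expected at about 100000 nM, with a range from 20000 nM to 500000 nM. The expected step is a step that the limit leaves unreadable from compound 3 to compound 4.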

Compound 4, half-maximal inhibitory concentration: > 63000 nM
Compound 4 was reported as a limit (the forecaster's own chance of this, stated with the estimate: 85%); the middle value lies beyond the limit too.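

Compound 4 gives only a limit, and its steps to compound 1, compound 2 and compound 3 cannot be read: the limit of > 63000 nM in this assay, at which 4 of the 4 values shown sit.

The compounds shown leave open whether any substituent on the benzyl ether of the shared core alters inhibition in this assay.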